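Trimming Ethyl to Methyl on the Thiocarbonyl Nitrogen

The compounds below may be only part of what the source reports. "The series", "measured", "known", "first", "only" and "open" are said of these compounds alone.

Measured so far:
Compound 1 `Nc1ccccc1NC(=O)c1ccc(CSC(=S)N2CCN(Cc3ccccn3)CC2)cc1`: 61.4%
Compound 2 `Nc1ccccc1NC(=O)c1ccc(CSC(=S)N2CCCc3ccccc32)cc1`: 35.7%
Compound 3 `CCN(Cc1ccncc1)C(=S)SCc1ccc(C(=O)Nc2ccccc2N)cc1`: 77.7%

These three share one core and differ only in the group on the thiocarbonyl carbon. In a functional assay on HeLa cells (Homo sapiens) for antiproliferative activity, read by CCK-8 assay, with a stated time of 72 h, tested at 8 uM (on this read-out lower numbers stand for a weaker effect and higher numbers for a stronger effect at the one concentration tested), compound 3 stands highest, with compound 1 the nearest and compound 2 the furthest below it. Among the measured compounds shown here, the one step between neighbours, a number 42 percentage points higher from compound 2 to compound 3 (beyond the scatter), swaps a whole ring system for an open chain and is large. Compound 4 `CN(Cc1ccncc1)C(=S)SCc1ccc(C(=O)Nc2ccccc2N)cc1` is the next neighbour of compound 3: hydrogen in place of methyl on a saturated chain carbon bound to an amide-type nitrogen. For the measured compounds named here, no measured step touches that chain alone, and the change is far smaller than the swap in compound 2, so the expected step of a number 5.7 percentage points lower from compound 3 to compound 4 (within the scatter) is small, if any, in either direction. Compound 4 is therefore estimated at 72%, between 55% and 88%.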

Compound 4, a percentage reported as inhibition, at one concentration (the size of the read-out at that concentration, not a potency): 72.7%
For compound 4 the middle estimate is 0.7 percentage points below the measured one, within the range that was stated.
By their numbers in this assay, from the lowest: compound 2; then compound 1; then compounds 4 and 3 (each within the scatter of the next).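

In this assay the trim from ethyl to methyl gives a number 5 percentage points lower from compound 3 to compound 4 (within the scatter) and so shows that this chain can shorten without a change beyond the usual scatter. The large gain over the 1,2,3,4-tetrahydroquinolin-1-yl group also survives the trim, with a number 37 percentage points higher from compound 2 to compound 4 (beyond the scatter) for the methyl((pyridin-4-yl)methyl)amino group, so that gain does not rest on ethyl alone. Nothing shown here gives a reason for either step.

The compounds shown leave open how a longer chain such as propyl or butyl would read at this place. They also leave open what a hydrogen directly on that nitrogen, giving a secondary amine, would do.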